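The source may hold more compounds than are shown below. What is called first, only, known or untested is meant among the compounds shown, and "the series" means these compounds.

Measured in a functional assay on LOX IMVI cells (Homo sapiens) for antiproliferative activity, read by sulforhodamine B assay, with a stated time of 48 h; a lower number here means a stronger inhibitor, a higher number a weaker inhibitor:
- compound 1 `C/C=C(\C)C(=O)O[C@H]1C=CC(=O)O[C@H]1CCC(=O)[C@H](C)O`: 24000 nM
- compound 2 `C/C=C(\C)C(=O)O[C@H]1C=CC(=O)O[C@H]1COC(=O)[C@H](C)O`: 13000 nM

Among the measured compounds shown here, only one comparison is available for compound 2, and it shows a 1.8-fold lower number from compound 1 to compound 2 (0.27 log units; within the scatter). Compound 2 and compound 1 therefore stand level within the scatter. Compound 3 `C/C=C(\C)C(=O)O[C@H]1C=CC(=O)O[C@H]1CNC(=O)[C@H](C)O` is not yet measured. It carries ((1-hydroxyethyl)carbonyl)amino in place of ((1-hydroxyethyl)carbonyl)oxy on a saturated chain carbon bound to a saturated ring carbon. For the measured compounds named here, the single measured step falls at this same place and stayed within the scatter, but no measured compound carries the amino group, so the evidence is thin. No step beyond the scatter is expected in this assay, and no direction can be argued from these data. The estimate amounts to a 1.2-fold higher number from compound 2 to compound 3 (0.06 log units; within the scatter), an expected step within the scatter. For compound 3 the estimated value is 15000 nM, with an expected range of 6000 nM to 40000 nM.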

Compound 3, half-maximal inhibitory concentration: 28000 nM
The estimate for compound 3 lay 1.9-fold (0.27 log units) below the measured number; the measured number falls inside the stated range.
By their numbers in this assay, from the lowest: compounds 2, 1 and 3 (each within the scatter of the next, the first and the last beyond it).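

Among the compounds shown here, at the place on a saturated chain carbon bound to a saturated ring carbon, ((1-hydroxyethyl)carbonyl)amino in place of ((1-hydroxyethyl)carbonyl)oxy gives the first step beyond the scatter in this assay (a 2.2-fold higher number from compound 2 to compound 3 (0.33 log units; beyond the scatter)), so the choice of group here is not wholly without effect, although the step is modest. ((1-hydroxyethyl)carbonyl)amino in place of ((1-hydroxyethyl)carbonyl)methyl, by contrast, stays within the scatter (a 1.2-fold higher number from compound 1 to compound 3 (0.07 log units; within the scatter)), leaving compound 1 and compound 3 level. Nothing available here accounts for the difference between these two steps.

The compounds shown leave open whether a sulfonamide or a plain ether at this place would shift the number further. They also do not tell whether a longer chain, or removal of the hydroxyl group from the 1-hydroxyethyl part, would matter.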